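Second Chloro on the Shared Core: Cytotoxicity Expected Unchanged

The compounds below may be only part of what the source reports. "The series", "measured", "known", "first", "only" and "open" are said of these compounds alone.

Compound 1 `ClCc1ccc(Cn2cnc3c(Cl)ncnc32)cc1`: > 100000 nM
Compound 2 `ClCc1cccc(Cn2cnc3c(Cl)ncnc32)c1`: > 100000 nM

In a functional assay on SK-MEL-2 cells (Homo sapiens) for cytotoxicity, read by sulforhodamine B assay, with a stated time of 48 h (on this read-out higher numbers stand for lower toxicity in this test and lower numbers for higher toxicity in this test), compound 1 gives only a limit of the assay, > 100000 nM. Compound 2 also gives only a limit in this assay, > 100000 nM. Compound 1 thus stands at the limit of > 100000 nM in this assay, at which 2 of the 2 values shown sit, and no numbered value is at hand. Compound 3 `ClCc1ccc(Cn2cnc3c(Cl)nc(Cl)nc32)cc1` differs from compound 1 by chloro in place of hydrogen on an aromatic carbon. For the measured compounds named here, no measured step covers such a change here, so no shift beyond the scatter is expected. Compound 3 is expected to give 100000 nM, between 30000 nM and 300000 nM, an expected step of a number no higher from compound 1 to compound 3 (the limit leaves the size open).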

Compound 3, concentration lethal to 50% of the cells: 95500 nM
Compound 3: the middle estimate sits 1.0-fold (0.02 log units) above what was measured, and the stated range covers the measured number.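

On the aromatic carbon between two ring nitrogen atoms, chloro in place of hydrogen gives in this assay an at least 1.0-fold lower number from compound 1 to compound 3 (0.01 log units; that floor lies within the scatter). Compound 3 thus supplies the first numbered value on the shared core, and this change brings no shift that can be shown to lie beyond the scatter. The true size of the step stays open, as the other values shown are limits: the limit of > 100000 nM in this assay, at which 2 of the 3 values shown sit.

The compounds shown leave open whether an amine or a methoxy group at this position would give a number beyond the scatter.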